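A few compounds are considered here, and "the series" means these few. Any claim that something is new, unique, unknown or untested is made for them only; others in the source may bear on it.

Of the compounds shown here, three sharing one core have been measured in a functional assay on the whole organism (artery, strain albino) with Rattus norvegicus as the target, with a stated time of 300 min, at a dose of 10 mg/kg by the oral route; on this read-out lower numbers stand for less inhibition and higher numbers for more inhibition at the one dose given (going by the name of the read-out). Compound 1, `CC1=C(C(=O)Nc2ccc(Br)cc2)C(c2ccc(Cl)cc2Cl)N=C(SCc2cccc(Cl)c2)N1`, carries a 3-chlorobenzyl group on its sulfur and a 2,4-dichlorophenyl group on the saturated ring carbon; in this assay compound 1 gives 18.5%. Compound 2, `CC1=C(C(=O)Nc2ccc(Br)cc2)C(c2ccc(Cl)cc2Cl)N=C(SCc2ccc(Cl)cc2)N1`, differs from compound 1 only in that (4-chlorophenyl in place of 3-chlorophenyl on a saturated chain carbon bound to a sulfur), and this change produced a step of a number 20 percentage points higher from compound 1 to compound 2 (beyond the scatter), so that in this assay compound 2 gives 38.5%. Compound 3, `COc1ccc(C2N=C(SCc3cccc(Cl)c3)NC(C)=C2C(=O)Nc2ccc(Br)cc2)cc1`, differs from compound 1 in that (4-methoxyphenyl in place of 2,4-dichlorophenyl on a saturated ring carbon), a change of the core itself; it produced a step of a number 20.5 percentage points higher from compound 1 to compound 3 (beyond the scatter), and in this assay compound 3 gives 39%. The values of compound 2 and compound 3 lie within the usual scatter of each other, so no order can be read between them.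

Compound 4, `COc1ccc(C2N=C(SCc3ccc(Cl)cc3)NC(C)=C2C(=O)Nc2ccc(Br)cc2)cc1`, has not yet been measured. It differs from compound 3 in that (4-chlorophenyl in place of 3-chlorophenyl on a saturated chain carbon bound to a sulfur), the same change, at the same place, that separates compound 2 from compound 1. For the measured compounds named here, the only guide to its effect is the step of a number 20 percentage points higher from compound 1 to compound 2 (beyond the scatter), seen once and on a different core. A somewhat smaller step is expected from compound 3 to compound 4, estimated at a number 11 percentage points higher from compound 3 to compound 4 (beyond the scatter), because compound 3 already gives 39%, higher than the starting point of the earlier step. Compound 4 is accordingly expected to give about 50%, with a range from 35% to 65%.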

Compound 4, a percentage reported as inhibition, in the whole organism at one dose (the size of the read-out at that dose, not a potency): 37.9%
The estimate for compound 4 lay 12.1 percentage points above the measured number; low and high end bracket the measured number.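

In this assay, putting 4-chlorophenyl in place of 3-chlorophenyl on the chain carbon bound to sulfur gave a number 1.1 percentage points lower from compound 3 to compound 4 (within the scatter), so the gain seen on the core of compound 1 did not carry over to the core with the 4-methoxyphenyl group: the same change on two cores in this assay, a number 20 percentage points higher (beyond the scatter) from compound 1 to compound 2 and a number 1.1 percentage points lower (within the scatter) from compound 3 to compound 4, 21.1 percentage points apart, beyond the scatter of two such steps The other change reads the same way, since 4-methoxyphenyl in place of 2,4-dichlorophenyl gave a number 0.6 percentage points lower from compound 2 to compound 4 (within the scatter), although it had raised the number when the 3-chlorobenzyl group was present: the same change on two cores in this assay, a number 20.5 percentage points higher (beyond the scatter) from compound 1 to compound 3 and a number 0.6 percentage points lower (within the scatter) from compound 2 to compound 4, 21.1 percentage points apart, beyond the scatter of two such steps In these four compounds, each change raises the number when made alone from compound 1, and making both adds nothing further, but this rests on a single set of four compounds at one dose and does not show why the two changes fail to add up.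

Still open, from the compounds shown here alone, is whether the same holds with other groups, such as a plain benzyl on the sulfur or a plain phenyl on the saturated ring carbon. Going by these compounds, all four compounds also keep the 4-bromophenyl amide, so it remains unknown how a plain phenyl or a carboxylic acid at that place would affect either step.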